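Swapping the Aryl Group Back Toward Methoxy

This account rests on a few compounds, and the source may have more. Where it says the series, first, only, none or still open, it means among the compounds named here.

Three compounds have been tested in an assay on BAF cells for inhibition of ribosomal protein S6 kinase alpha-2 (Mus musculus); a higher number here means a weaker inhibitor, a lower number a stronger inhibitor:

compound 1, `COc1ccccc1-c1cccc2nc(Nc3cc(OC)c(OC)c(OC)c3)oc12`: 5700 nM
compound 2, `COc1cc(Nc2nc3cccc(-c4ccccc4OC(F)(F)F)c3o2)cc(OC)c1OC`: > 20000 nM (a limit of the assay, not a number)
compound 3, `COc1cc(Nc2nc3cccc(-c4c(F)cccc4OC(C)C)c3o2)cc(OC)c1OC`: > 20000 nM (a limit of the assay, not a number)

Compound 3 therefore stands at the upper limit of this assay, together with compound 2, with no number of its own (the limit of > 20000 nM in this assay, at which 2 of the 3 values shown sit). Compound 1 is the only one of the three with a measured value.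

Compound 4, `COc1ccc(F)cc1-c1cccc2nc(Nc3cc(OC)c(OC)c(OC)c3)oc12`, differs from compound 3 in one place: a group of 9 heavy atoms (7 carbon, 1 oxygen, 1 fluorine; one six-membered aromatic ring of carbon only) in place of a group of 11 heavy atoms (9 carbon, 1 oxygen, 1 fluorine; one six-membered aromatic ring of carbon only), on an aromatic carbon. The new group, 5-fluoro-2-methoxyphenyl, resembles the group carried by compound 1 more closely than the group carried by compound 3 does.

Within the data shown here, two measured steps bear on this change. From compound 1 to compound 3 the assay gave an at least 3.5-fold higher number from compound 1 to compound 3 (0.54 log units; beyond the scatter), and from compound 1 to compound 2 it gave an at least 3.5-fold higher number from compound 1 to compound 2 (0.54 log units; beyond the scatter). The step from compound 2 to compound 3 is a step that the two limits leave unreadable from compound 2 to compound 3. Compound 4 moves part of the way back toward compound 1, so a step downward, toward a stronger inhibitor, is expected in this assay, roughly an at least 3.3-fold lower number from compound 3 to compound 4 (0.52 log units; beyond the scatter), though only compound 1 anchors that expectation.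

Compound 4 is therefore estimated at 6000 nM, between 2000 nM and 20000 nM.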

Compound 4, half-maximal inhibitory concentration: 3700 nM
Compound 4: the middle estimate sits 1.6-fold (0.21 log units) above what was measured; the measured number falls inside the stated range.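

In this assay, fluoro in place of hydrogen on the 2-methoxyphenyl group gives a 1.5-fold lower number from compound 1 to compound 4 (0.19 log units; within the scatter), so this fluoro leaves no readable mark on the result, and a ring carrying fluoro at this position of the molecule can still give a measurable value. Compound 4 also gives a clear separation from the two compounds whose aryl groups carry something other than methoxy on the oxygen, with an at least 5.4-fold lower number from compound 3 to compound 4 (0.73 log units; beyond the scatter) and an at least 5.4-fold lower number from compound 2 to compound 4 (0.73 log units; beyond the scatter); the first of these swaps the whole aryl group, so it cannot be pinned on the group on the oxygen alone, since the fluoro sits elsewhere on the ring in compound 3. Compound 2 and compound 3 each carry only a limit, so both steps give a minimum size and not a true one: the limit of > 20000 nM in this assay, at which 2 of the 4 values shown sit.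

Going by these compounds, whether an ethoxy group on the oxygen would stay with the methoxy compounds or fall to the limit remains open. So does what a hydroxyl or an amine would do in place of the methoxy on this aryl group.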